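The compounds below may be only part of what the source reports. "The series", "measured", "known", "first", "only" and "open" are said of these compounds alone.

For the measured compounds named here, compound 3 `C=C(Br)C(=O)Nc1ccc(/C=C2\SC(=O)N(Cc3ccc(C(F)(F)F)cc3)C2=O)cc1` gives 8000 nM in a functional assay on CCRF-CEM cells (Homo sapiens) for cytotoxicity, read by cell counting, with a stated time of 3 days (a higher number here means a weaker inhibitor, a lower number a stronger inhibitor), the second highest of the three numbers so far: compound 2 `C=C(Br)C(=O)Nc1ccc(/C=C2\SC(=O)N(Cc3ccc(F)cc3)C2=O)cc1` gives 2400 nM and compound 1 `CC(C)(C)c1ccc(CN2C(=O)S/C(=C\c3ccc(N)cc3)C2=O)cc1` gives 66000 nM. Compound 4 `C=C(Br)C(=O)Nc1ccc(/C=C2\SC(=O)N(Cc3ccc(C(C)(C)C)cc3)C2=O)cc1` differs from compound 3 in one place: tert-butyl in place of trifluoromethyl on an aromatic carbon. Of the measured steps only a 3.3-fold higher number from compound 2 to compound 3 (0.52 log units; beyond the scatter) bears on this change, as it alters the same group in the same place; compound 1 also carries a tert-butyl but differs elsewhere too, so its value is only a loose pointer. A modest rise in the number, or none beyond the scatter, is expected, with the expected step of a 1.4-fold higher number from compound 3 to compound 4 (0.14 log units; within the scatter). Compound 4 is estimated at 11000 nM in this assay, within a range from 3500 nM to 35000 nM.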

Compound 4, half-maximal inhibitory concentration: 830 nM
Beside the measured number, compound 4's estimate is 13-fold (1.12 log units) above it; measured number below the stated range.
By their numbers in this assay, from the lowest: compound 4; then compound 2; then compound 3; then compound 1.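

In this assay, tert-butyl in place of trifluoromethyl gives a 9.6-fold lower number from compound 3 to compound 4 (0.98 log units; beyond the scatter), and tert-butyl in place of fluoro gives a 2.9-fold lower number from compound 2 to compound 4 (0.46 log units; beyond the scatter), so the earlier step from fluoro to trifluoromethyl did not predict where tert-butyl would fall. With tert-butyl held fixed, (1-bromoethenyl)carbonyl in place of hydrogen on the nitrogen gives an 80-fold lower number from compound 1 to compound 4 (1.90 log units; beyond the scatter). No evidence is available to explain these differences. On these data alone, it remains open how an isopropyl group, a methoxy group or an amine would fare on this aromatic carbon.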